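The source may report more compounds than this note shows. Statements on the series, on what has been measured and on what is new or still open speak of the compounds shown alone.

Measured so far in a functional assay on B16-F10 cells (Mus musculus) for inhibition, read by MTT assay, with a stated time of 72 h; on this read-out lower numbers stand for stronger inhibition and higher numbers for weaker inhibition:
compound 1, `Cc1ccc(-c2nc(SCc3cn(CC(=O)NC(=O)Nc4ccccn4)nn3)nc(Nc3ccc(C(C)C)cc3)c2C#N)cc1`, where compound 1 gives 35 nM;
compound 2, `Cc1ccc(-c2nc(SCc3cn(CC(=O)NC(=O)Nc4ccccn4)nn3)nc(Nc3cccc(C(F)(F)F)c3)c2C#N)cc1`, where compound 2 gives 9580 nM;
compound 3, `N#Cc1c(Nc2cccc(C(F)(F)F)c2)nc(SCc2cn(CC(=O)NC(=O)Nc3ccccn3)nn2)nc1-c1ccc(Br)cc1`, where compound 3 gives 4550 nM.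

Compound 3 stands second highest of the three; the step from compound 2 to compound 3 was a 2.1-fold lower number from compound 2 to compound 3 (0.32 log units; beyond the scatter), and the two cores differ by bromo in place of methyl on an aromatic carbon.

Compound 4, `CC(C)c1ccc(Nc2nc(SCc3cn(CC(=O)NC(=O)Nc4ccccn4)nn3)nc(-c3ccc(Br)cc3)c2C#N)cc1`, has not yet been measured in this assay. It differs from compound 3 by 4-isopropylphenyl in place of 3-(trifluoromethyl)phenyl on a nitrogen on an aromatic ring. This same change has been measured once already, from compound 2 to compound 1, where it reads 4-isopropylphenyl in place of 3-(trifluoromethyl)phenyl on a nitrogen on an aromatic ring and gave a 270-fold lower number from compound 2 to compound 1 (2.44 log units; beyond the scatter). The place of the change is described in the same words in both pairs, so it is the same change carried onto a core that differs only by the bromo group.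

Because the earlier example gave a 270-fold lower number from compound 2 to compound 1 (2.44 log units; beyond the scatter), a step of similar size is expected from compound 3 to compound 4, namely a 230-fold lower number from compound 3 to compound 4 (2.36 log units; beyond the scatter). With a single prior example the expectation is uncertain. Compound 4 is estimated at 20 nM, most likely between 5 nM and 90 nM.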

Compound 4, half-maximal inhibitory concentration: 42 nM
Compound 4: the middle estimate sits 2.1-fold (0.32 log units) below what was measured, and the stated range covers the measured number.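

In this assay, putting 4-isopropylphenyl in place of 3-(trifluoromethyl)phenyl on the bromo core gave a 110-fold lower number from compound 3 to compound 4 (2.03 log units; beyond the scatter), so the large step seen on the methyl core carried over, and the two steps agree: the same change on two cores in this assay, a 270-fold lower number (2.44 log units; beyond the scatter) from compound 2 to compound 1 and a 110-fold lower number (2.03 log units; beyond the scatter) from compound 3 to compound 4, 2.5-fold (0.40 log units) apart, within the scatter of two such steps. The reverse comparison also holds together, as bromo in place of methyl gave a 1.2-fold higher number from compound 1 to compound 4 (0.08 log units; within the scatter) with 4-isopropylphenyl on the nitrogen, which does not differ from its counterpart on the other pair of compounds: the same change on two cores in this assay, a 2.1-fold lower number (0.32 log units; beyond the scatter) from compound 2 to compound 3 and a 1.2-fold higher number (0.08 log units; within the scatter) from compound 1 to compound 4, 2.5-fold (0.40 log units) apart, within the scatter of two such steps. This shows that the change carries between two cores that differ only by bromo or methyl, but it does not show that it would carry to a core altered anywhere else, and it gives no reason for the size of the step.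

In every pair shown, the isopropyl group arrives as the trifluoromethyl group leaves, so a plain phenyl on that nitrogen would be needed to tell the two apart. Going by these compounds, how a tert-butyl group in place of the isopropyl, or a chloro or methoxy group in place of the bromo, would read remains open.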